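Three Cytotoxicity Readings and an Isopropyl Replacement

The source may hold more compounds than are shown below. What is called first, only, known or untested is meant among the compounds shown, and "the series" means these compounds.

compound 1 `C=C1C(=O)OC[C@H]1CCOC(=O)Nc1ccc(I)cc1`: 12800 nM in an ADME assay on RAW264.7 cells (Mus musculus) for cytotoxicity, read by MTT assay, with a stated time of 18 h; on this read-out lower numbers stand for higher toxicity in this test and higher numbers for lower toxicity in this test
compound 2 `C=C1C(=O)OC[C@@H]1CCOC(=O)Nc1ccc(I)cc1`: 12500 nM
compound 3 `C=C1C(=O)OC[C@@H]1CCOC(=O)Nc1ccc(Cl)cc1`: 10300 nM

Compound 1 gives the highest of the three numbers, yet the gaps to the others are small: a 1.0-fold lower number from compound 1 to compound 2 (0.01 log units; within the scatter), which rests on (the fact that compounds 1 and 2 differ only in the configuration as drawn), and a 1.2-fold lower number from compound 2 to compound 3 (0.08 log units; within the scatter). Compound 4 `C=C1C(=O)OC[C@H]1CCOC(=O)Nc1ccc(C(C)C)cc1` is not yet measured; it alters compound 1 by isopropyl in place of iodo on an aromatic carbon. For the measured compounds named here, the step that bears most on this change is the one from compound 2 to compound 3, where one halogen replaced another at the same aromatic carbon and the number stayed within the scatter. Isopropyl is no halogen, so that guide is thin, and a step of about a 1.1-fold lower number from compound 1 to compound 4 (0.03 log units; within the scatter) is expected. Compound 4 is estimated at 12000 nM, with a range from 6000 nM to 25000 nM.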

Compound 4, half-maximal cytotoxic concentration: 12400 nM
The estimate for compound 4 lay 1.0-fold (0.01 log units) below the measured number; measured number inside the range.
By their numbers in this assay, from the lowest: compounds 3, 4, 2 and 1 (each within the scatter of the next).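

Earlier, this aromatic carbon showed only one halogen exchanged for another. Here isopropyl, with 3 heavy atoms, replaces iodo, a single iodine, and this assay still gives a 1.0-fold lower number from compound 1 to compound 4 (0.01 log units; within the scatter), so within this set a halogen is not required at this position for a number in this range. Nothing available explains this result. The compounds shown leave open whether an amine or a carboxylic acid at this carbon would also leave the number unchanged. They also leave open whether isopropyl would give the same reading on the core as configured in compound 2.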